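Swapping a Pyrrolidinyl for a Hydroxyethoxy Group on Compound 2

The source may hold more compounds than are shown below. What is called first, only, known or untested is meant among the compounds shown, and "the series" means these compounds.

Compound 1 `CCCCCOC(=O)N1CCN(C(=O)[C@H](CCC(=O)O)NC(=O)c2cc(N3CCC(C(=O)N4CCCC4)CC3)nc(-c3ccccc3)n2)CC1` gives in an ADME assay on microsomes from liver (Rattus norvegicus) for metabolic stability (a higher number here means that more of the compound is left, a lower number that less of the compound is left), a value of > 80%, which is a limit of the assay. Compound 2 `CCCCCOC(=O)N1CCN(C(=O)[C@H](CCC(=O)O)NC(=O)c2cc(N3CCC(N4CCCC4)CC3)nc(-c3ccccc3)n2)CC1` gives in this assay a value of > 80%, again a limit.

Compound 2 stands at the upper edge of what the assay reports: the limit of > 80% in this assay, at which 2 of the 2 values shown sit. Going by the values given here, the only measured step at this position, a step that the two limits leave unreadable from compound 1 to compound 2, cannot be sized, since both ends sit at that limit.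

Compound 3 `CCCCCOC(=O)N1CCN(C(=O)[C@H](CCC(=O)O)NC(=O)c2cc(N3CCC(OCCO)CC3)nc(-c3ccccc3)n2)CC1` carries the change (2-hydroxyethoxy in place of pyrrolidin-1-yl on a saturated ring carbon). The step from compound 1 to compound 2 bears on it in place but not in size, so no direction can be read from it; the two values shown merely agree that the molecule stays largely intact regardless of what sits on that saturated ring carbon. Against that background the step from compound 2 to compound 3 is expected to be a step that the limit leaves unreadable from compound 2 to compound 3, which is no change beyond the scatter. For compound 3 the expected value in this assay is therefore 82%, with a range from 55% to 98%.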

Compound 3, percent of the compound remaining: > 80%
Compound 3 gave a limit, no number; the forecaster's own chance of this, stated with the estimate: 55%; the middle value does not contradict the limit.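

In this assay compound 3 gives > 80% as a limit of the assay, not a number. Going by these compounds alone, no step among compound 1, compound 2 and compound 3 can be read, since all three sit at the same edge: the limit of > 80% in this assay, at which 3 of the 3 values shown sit. The compounds shown leave open how much of each one actually remains and whether the three differ at all.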